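The source may hold more compounds than are shown below. What is called first, only, known or untested is meant among the compounds shown, and "the series" means these compounds.

In an assay for inhibition of HSP60/HSP10 (Homo sapiens), with a stated time of 60 min (on this read-out higher numbers stand for weaker inhibition and lower numbers for stronger inhibition), compound 2 `O=S(=O)(Nc1ccc(-c2nc3cc(NS(=O)(=O)c4cccc(C(F)(F)F)c4)ccc3o2)cc1)c1cccc(C(F)(F)F)c1` gives 58000 nM, the higher of the two numbers recorded so far. Among the compounds with values here, compound 1 `O=S(=O)(Nc1ccc2oc(-c3ccc(NS(=O)(=O)c4ccc(Cl)s4)cc3)nc2c1)c1ccc(Cl)c(Cl)c1` gives 4700 nM in this assay, a smaller number, and no single-change step links the two. Compound 3 `O=S(=O)(Nc1ccc(-c2nc3cc(NS(=O)(=O)c4ccc(Cl)s4)ccc3o2)cc1)c1cccc(C(F)(F)F)c1` differs from compound 2 by 5-chlorothiophen-2-yl in place of 3-(trifluoromethyl)phenyl on a sulfonyl sulfur. Within the data shown here, no measured pair shows this change. The expected step in this assay is a 2.9-fold lower number from compound 2 to compound 3 (0.46 log units; beyond the scatter), a moderate move toward a lower number. This rests on compound 1, which gives 4700 nM with 5-chlorothiophen-2-yl on one sulfonyl sulfur. Compound 3 is estimated at 20000 nM, within 6000 nM to 60000 nM.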

Compound 3, half-maximal inhibitory concentration: 4500 nM
Beside the measured number, compound 3's estimate is 4.4-fold (0.65 log units) above it; the whole stated range lies above it.
By their numbers in this assay, from the lowest: compounds 3 and 1 (each within the scatter of the next); then compound 2.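

In this assay, within the data shown here, the first single-place reading is a 13-fold lower number from compound 2 to compound 3 (1.11 log units; beyond the scatter), from 5-chlorothiophen-2-yl replacing 3-(trifluoromethyl)phenyl on a sulfonyl sulfur. This substituent alone therefore carries a large effect, even with 3-(trifluoromethyl)phenyl still on the other sulfonyl sulfur of compound 3. No available evidence explains the step.

As far as these compounds go, whether the same change on the other sulfonyl sulfur gives a similar step remains open. Also open, from the compounds shown here alone, is how an unsubstituted thiophen-2-yl, a carboxylic acid or an amine would read at this position.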